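Shortening the side chain bound to the amide nitrogen

A few compounds are considered here, and "the series" means these few. Any claim that something is new, unique, unknown or untested is made for them only; others in the source may bear on it.

Measured so far:
compound 1, `CC(C)[C@H](NC(=O)c1ccc(C(=O)Nc2ccc3c(c2)C(C)(C)CCC3(C)C)cc1)C(=O)OCc1c(-c2ccccc2)no[n+]1[O-]`: 4390 nM in a functional assay on NB-4 cells (Homo sapiens) for antiproliferative activity, read by MTT assay, with a stated time of 48 h; a lower number here means a stronger inhibitor, a higher number a weaker inhibitor
compound 2, `C[C@H](NC(=O)c1ccc(C(=O)Nc2ccc3c(c2)C(C)(C)CCC3(C)C)cc1)C(=O)OCc1c(-c2ccccc2)no[n+]1[O-]`: 5100 nM in this assay

Compound 2 holds the highest of the two numbers, but only just: a 1.2-fold higher number from compound 1 to compound 2 (0.07 log units; within the scatter), so the pair stands as equals on this assay. Compound 3, `CC1(C)CCC(C)(C)c2cc(NC(=O)c3ccc(C(=O)NCC(=O)OCc4c(-c5ccccc5)no[n+]4[O-])cc3)ccc21`, carries the same trimming one step further: hydrogen in place of methyl on a saturated chain carbon bound to an amide-type nitrogen and a carbonyl carbon. Among the compounds with values here, the only measured step that bears on this change is the earlier replacement of isopropyl by methyl at the same place, and that step stayed within the scatter. On that basis no step beyond the scatter is expected here, though a small drift in the same direction as before is allowed for; the expected step is a 1.1-fold higher number from compound 2 to compound 3 (0.04 log units; within the scatter). Compound 3 is therefore estimated at 5600 nM in this assay, with a range of 3000 nM to 10500 nM.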

Compound 3, half-maximal inhibitory concentration: 190 nM
Compound 3: middle estimate off by 29-fold (1.47 log units), on the high side; the measured number lies below the stated range.
By their numbers in this assay, from the lowest: compound 3; then compounds 1 and 2 (each within the scatter of the next).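

At the saturated chain carbon bound to an amide-type nitrogen and a carbonyl carbon, the large change in this assay comes only when the carbon side chain is removed altogether. Hydrogen in place of methyl gives a 27-fold lower number from compound 2 to compound 3 (1.43 log units; beyond the scatter) and hydrogen in place of isopropyl gives a 23-fold lower number from compound 1 to compound 3 (1.36 log units; beyond the scatter), whereas isopropyl and methyl stand as equals. Among these compounds, the position therefore shows no graded trend, only a sharp break between hydrogen and either carbon side chain, and nothing available accounts for that break.

Still open, from the compounds shown here alone, is where a longer chain, a hydroxymethyl group or an aminomethyl group would fall relative to compound 3 and the pair of compound 1 and compound 2. Also open, going by these compounds, is whether the break persists when the phenyl group or the ester of compound 3 is replaced.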